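A few compounds are considered here, and "the series" means these few. Any claim that something is new, unique, unknown or untested is made for them only; others in the source may bear on it.

Compound 1 `CC[C@H](C)[C@H](N)CN(C(=O)[C@@H]1C[C@H]1c1ccc(Cl)cc1)c1ccc(-c2ccccc2)cc1`: in a functional assay for agonist activity at G protein-coupled receptor 88 (Homo sapiens), read by HTRF and cAMP accumulation (on this read-out lower numbers stand for an effect already at smaller amounts and higher numbers for an effect only at larger amounts of compound), compound 1 gives 4300 nM.
Compound 2 `CCCc1ccc(-c2ccc(N(C[C@@H](N)[C@@H](C)CC)C(=O)[C@@H]3C[C@H]3c3ccccc3)cc2)cc1`: in this assay compound 2 gives 61 nM.

Within the data shown here, compound 2 stands lowest of the two numbers; the only other value, that of compound 1, is markedly higher, beyond the scatter. Compound 3 `CC[C@H](C)[C@H](N)CN(C(=O)[C@@H]1C[C@H]1c1ccccc1)c1ccc(-c2ccc(OC(C)C)cc2)cc1` differs from compound 2 by isopropoxy in place of propyl on an aromatic carbon. Among the measured compounds shown here, no measured pair shows this change, so the expectation rests on compound 2 alone. A step of modest size toward a higher number is expected, a 1.5-fold higher number from compound 2 to compound 3 (0.17 log units; within the scatter), close to the scatter. Compound 3 is therefore estimated at 90 nM, within a range from 25 nM to 350 nM.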

Compound 3, half-maximal effective concentration: 72 nM
Beside the measured number, compound 3's estimate is 1.3-fold (0.10 log units) above it, and the stated range covers the measured number.
By their numbers in this assay, from the lowest: compounds 2 and 3 (each within the scatter of the next); then compound 1.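

Reading this assay, the change from 4-propylphenyl to 4-isopropoxyphenyl gives a 1.2-fold higher number from compound 2 to compound 3 (0.07 log units; within the scatter). At this place, on an aromatic carbon para to a large group, the position therefore takes isopropoxy in place of propyl with no difference beyond the scatter, even though the entering group brings an oxygen and a hydrogen-bond acceptor. From the compounds shown here alone, what remains open is how an amine, a carboxylic acid or a longer chain would read at this position. Nothing on hand accounts for this result.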